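A Urea Variant Against the Breast Cancer Cell Line

The source may hold more compounds than are shown below. What is called first, only, known or untested is meant among the compounds shown, and "the series" means these compounds.

Compound 1, `O=C(Nc1cccc(-c2nc(-c3ccc(NC(=O)c4cccnc4)cc3Cl)no2)c1)c1ccccc1`, in a functional assay on MDA-MB-231 cells (Homo sapiens) for antiproliferative activity, read by MTT assay, with a stated time of 72 h (a higher number here means a weaker inhibitor, a lower number a stronger inhibitor), gives 12800 nM.
Compound 2, `Cc1ccc(S(=O)(=O)Nc2cccc(-c3nc(-c4ccc(NC(=O)c5cccnc5)cc4Cl)no3)c2)cc1`, gives > 10000 nM, which is a limit of this assay and not a number.
Compound 3, `C#Cc1cccc(NC(=O)Nc2cccc(-c3nc(-c4ccc(NC(=O)c5cccnc5)cc4Cl)no3)c2)c1`, gives > 10000 nM, again a limit.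

Compound 3 therefore stands at the limit, and of the three values shown two sit there (the limit of > 10000 nM in this assay, at which 2 of the 3 values shown sit). The step from compound 1 to compound 3 is a step that the limit leaves unreadable from compound 1 to compound 3, and the step from compound 2 to compound 3 is a step that the two limits leave unreadable from compound 2 to compound 3; neither can be read for size or direction, and the step from compound 1 to compound 2, a step that the limit leaves unreadable from compound 1 to compound 2, is unreadable too.

Compound 4, `CC(=O)Nc1ccc(NC(=O)Nc2cccc(-c3nc(-c4ccc(NC(=O)c5cccnc5)cc4Cl)no3)c2)cc1`, differs from compound 3 in one place: 4-acetamidophenyl in place of 3-ethynylphenyl on an amide-type nitrogen. Going by the values given here, the only measured step touching this part of the molecule, from compound 1 to compound 3, leaves its size unknown, so no read step bears on the exchange. Among the compounds with values here, compound 1, the one compound with a number, is itself weak in this assay, and compound 3 sits at the limit, so compound 4 is expected to remain weak; the expected step from compound 3 to compound 4 is a step that the limit leaves unreadable from compound 3 to compound 4. Compound 4 is estimated at 15000 nM, within 5000 nM to 50000 nM, with a fair chance that only a limit is reported.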

Compound 4, half-maximal inhibitory concentration: > 10000 nM
Compound 4: only a limit was reported; the forecaster's own chance of this, stated with the estimate: 65%; the middle value does not contradict the limit.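

Compound 4 gives > 10000 nM in this assay, which is a limit and not a number, so neither its step from compound 3 nor its step from compound 1 can be read for size or direction. The compounds shown leave open whether any group on this amide-type nitrogen gives a value that can be read against compound 1.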